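This account rests on a few compounds, and the source may have more. Where it says the series, first, only, none or still open, it means among the compounds named here.

Measured so far:
- compound 1, `Cc1ccc(-c2c3ccc4ccccc4c3nc3c2c(C)nc2c4ccccc4ccc32)cc1`: 123 ug/mL
- compound 2, `Cc1nc2c3ccccc3ccc2c2nc3c(ccc4ccccc43)c(-c3nccnc3N)c12`: 81.7 ug/mL
- compound 3, `Cc1nc2c3ccccc3ccc2c2nc3c(ccc4ccccc43)c(-c3ccc(O)cc3)c12`: 86.4 ug/mL

These three compounds share one large fused core and differ only in the aromatic group attached to it. In a functional assay, read by spectrophotometry, with a stated time of 30 min (on this read-out higher numbers stand for weaker inhibition and lower numbers for stronger inhibition), compound 1 gives the highest of the three numbers, but neither of its companions is far away: the step of a 1.5-fold lower number from compound 1 to compound 2 (0.18 log units; within the scatter) and the step of a 1.4-fold lower number from compound 1 to compound 3 (0.15 log units; within the scatter) both stay within the scatter, so no real order among the three can be claimed.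

Compound 4, `Cc1nc2c3ccccc3ccc2c2nc3c(ccc4ccccc43)c(-c3ccccc3N)c12`, is not yet measured. It differs from compound 1 in one place:

2-aminophenyl in place of 4-methylphenyl on an aromatic carbon

Within the data shown here, two measured steps bear on this. Replacing the 4-methylphenyl with a 3-aminopyrazin-2-yl, which also carries an amino group, gave a 1.5-fold lower number from compound 1 to compound 2 (0.18 log units; within the scatter); replacing the methyl with a hydroxy gave a 1.4-fold lower number from compound 1 to compound 3 (0.15 log units; within the scatter). Both brought a hydrogen-bond donor into the same spot and both left the number where it was, within the scatter. The change to compound 4 is of the same kind, so a step of similar size, leaning slightly toward a lower number but not beyond the scatter, is expected in this assay, that is a 1.4-fold lower number from compound 1 to compound 4 (0.14 log units; within the scatter). Compound 4 is therefore estimated at 90 ug/mL, with a range from 45 ug/mL to 180 ug/mL.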

Compound 4, half-maximal inhibitory concentration: 95.4 ug/mL
Compound 4: the middle estimate sits 1.1-fold (0.03 log units) below what was measured; the measured number falls inside the stated range.
By their numbers in this assay, from the lowest: compounds 2, 3, 4 and 1 (each within the scatter of the next).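

In this assay, 2-aminophenyl in place of 4-methylphenyl gives a 1.3-fold lower number from compound 1 to compound 4 (0.11 log units; within the scatter) and keeps a six-membered aromatic ring of carbon only, so this change adds a hydrogen-bond donor and acceptor on this aromatic carbon without putting nitrogen into the attached ring. Compared with the other two groups, the new one gives a 1.1-fold higher number from compound 3 to compound 4 (0.04 log units; within the scatter) and a 1.2-fold higher number from compound 2 to compound 4 (0.07 log units; within the scatter), which means that 2-aminophenyl, 4-hydroxyphenyl and 3-aminopyrazin-2-yl cannot be told apart on this read-out. All the steps among these four compounds therefore stay within the scatter, and no supporting data explain why the group at this position makes so little visible difference.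

Every group shown here attaches through an aromatic ring, so it remains open what a carboxylic acid or a saturated amine such as piperidine would do on the same carbon. The core is also the same in all four compounds, so these results say nothing about whether changes to it would move the number beyond the scatter.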